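The source may report more compounds than this note shows. Statements on the series, on what has been measured and on what is new or still open speak of the compounds shown alone.

Compound 1 `COC(=O)C1=C(C)N=C(C)/C(=C(\O)OC)C1c1ccccc1I` sits second highest of the three numbers in a functional assay (muscle tissue) with Cavia porcellus as the target (a lower number here means that less compound is needed, a higher number that more compound is needed for the effect), where compound 1 gives 46.8 nM. Compound 2 `COC(=O)C1=C(C)N=C(C)/C(=C(\O)OC)C1c1cc([N+](=O)[O-])ccc1Cl` gives 30.2 nM, within the scatter of compound 1, while compound 3 `COC(=O)C1=C(C)N=C(C)/C(=C(\O)OC)C1c1cc(C)ccc1C` gives 100 nM, reached by a 2.1-fold higher number from compound 1 to compound 3 (0.33 log units; beyond the scatter). Compound 4 `COC(=O)C1=C(C)N=C(C)/C(=C(\O)OC)C1c1cccc(OC)c1` differs from compound 1 in one place: 3-methoxyphenyl in place of 2-iodophenyl on a saturated ring carbon. Within the data shown here, no measured step swaps the 2-iodophenyl for a group lacking a substituent at the position the iodine held, so the only guide is the modest rise seen in a 2.1-fold higher number from compound 1 to compound 3 (0.33 log units; beyond the scatter) when the aryl group changed. Compound 4 is therefore expected to show a step of a 2.6-fold higher number from compound 1 to compound 4 (0.41 log units; beyond the scatter), modest and upward in this assay. Compound 4 is estimated at 120 nM, between 40 nM and 400 nM.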

Compound 4, half-maximal effective concentration: 191 nM
Estimate against measurement, compound 4: 1.6-fold (0.20 log units) below; the range from low to high includes it.
By their numbers in this assay, from the lowest: compounds 2 and 1 (each within the scatter of the next); then compounds 3 and 4 (each within the scatter of the next).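

In this assay, replacing the 2-iodophenyl gives a 4.1-fold higher number from compound 1 to compound 4 (0.61 log units; beyond the scatter) and so shows that a second aryl change away from compound 1 also moves the number up beyond the scatter. The 3-methoxyphenyl and 2,5-dimethylphenyl groups do not separate here, since a 1.9-fold higher number from compound 3 to compound 4 (0.28 log units; within the scatter) lies within the scatter. Nothing measured on these compounds accounts for the step. On these data alone, whether an unsubstituted phenyl, or an aryl ring carrying an amine or a carboxylic acid, would fall with compound 1 and compound 2 or with compound 3 and compound 4 stays open.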